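The source may hold more compounds than are shown below. What is called first, only, known or untested is meant among the compounds shown, and "the series" means these compounds.

Among the compounds with values here, compound 2 `CCCNC(=O)c1ccc2cc(C(O)(c3c[nH]cn3)C(C)C)ccc2c1` is one of two compounds measured in an assay on microsomes from Testis (strain Sprague-Dawley) for inhibition of steroid 17-alpha-hydroxylase/17,20 lyase (Rattus norvegicus); a lower number here means a stronger inhibitor, a higher number a weaker inhibitor. In this assay compound 2 gives 13 nM, the higher of the two numbers, and its nearest neighbour is compound 1 `CC(C)NC(=O)c1ccc2cc(C(O)(c3c[nH]cn3)C(C)C)ccc2c1`, which in this assay gives 12 nM; the step from one to the other, a 1.1-fold higher number from compound 1 to compound 2 (0.03 log units; within the scatter), lies within the scatter. The third compound, compound 3 `COC(=O)c1ccc2cc(C(O)(c3c[nH]cn3)C(C)C)ccc2c1`, has not been measured. It differs from compound 2 by methoxy in place of propylamino on a carbonyl carbon. Within the data shown here, the only measured step, a 1.1-fold higher number from compound 1 to compound 2 (0.03 log units; within the scatter), concerns a change of the group on the amide nitrogen and not the exchange of that nitrogen for an oxygen, so it bears on the new change only loosely. Since that one step was flat, compound 3 is expected to stay in the same region, with a step of a 1.9-fold higher number from compound 2 to compound 3 (0.28 log units; within the scatter) that is more likely to weaken than to strengthen. The estimate for compound 3 in this assay is therefore 25 nM, with a range from 8 nM to 80 nM.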

Compound 3, half-maximal inhibitory concentration: 43 nM
Compound 3: the middle estimate sits 1.7-fold (0.24 log units) below what was measured; the measured number falls inside the stated range.
By their numbers in this assay, from the lowest: compounds 1 and 2 (each within the scatter of the next); then compound 3.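

In this assay, the exchange at this carbonyl carbon moves the number beyond the scatter, which the swap of propyl for isopropyl on the amide nitrogen did not do: methoxy in place of propylamino gives a 3.3-fold higher number from compound 2 to compound 3 (0.52 log units; beyond the scatter), and methoxy in place of isopropylamino gives a 3.6-fold higher number from compound 1 to compound 3 (0.55 log units; beyond the scatter). Both steps point the same way, so replacing either amide with the methyl ester weakens inhibition modestly, and what stands on the carbonyl carbon matters more here than the shape of the group on the nitrogen. Nothing in the data gives a measured reason for this loss.

The change swaps nitrogen for oxygen, removes a hydrogen-bond donor and shortens the chain all at once, and the compounds shown do not separate these. Methylamino or propoxy on the same carbonyl carbon would begin to, and a carboxylic acid there remains an open case.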